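From 4-bromophenyl to thiophen-2-yl on a carbonyl carbon

The source may report more compounds than this note shows. Statements on the series, on what has been measured and on what is new or still open speak of the compounds shown alone.

Measured compounds in a functional assay on HeLa cells (Homo sapiens) for antiproliferative activity, with a stated time of 48 h; a higher number here means a weaker inhibitor, a lower number a stronger inhibitor
- compound 1 `C=C(Br)C(=O)Nc1ccc(/C=C/C(=O)c2ccc(Br)cc2)cc1` (1000 nM)
- compound 2 `C=C(Br)C(=O)Nc1ccc(/C=C/C(=O)c2cc(OC)c(OC)c(OC)c2)cc1` (1100 nM)
- compound 3 `C=C(Br)C(=O)Nc1ccc(/C=C/C(=O)c2cccc3ccccc23)cc1` (2000 nM)

Compound 1 (1000 nM) stands level with compound 2 and compound 3, since all three values lie within the usual scatter of one another. Compound 4 `C=C(Br)C(=O)Nc1ccc(/C=C/C(=O)c2cccs2)cc1` has not yet been measured. It carries thiophen-2-yl in place of 4-bromophenyl on a carbonyl carbon. For the measured compounds named here, no measured pair differs in one place only. Still, compound 2 (1100 nM) and compound 3 (2000 nM) carry other groups on that carbon without leaving the scatter of compound 1, so no change beyond the scatter is expected. The expected 1.3-fold higher number from compound 1 to compound 4 (0.11 log units; within the scatter) is small. Compound 4 is estimated at 1300 nM in this assay with 600 nM to 3000 nM as its expected range.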

Compound 4, half-maximal inhibitory concentration: 340 nM
Estimate against measurement, compound 4: 3.8-fold (0.58 log units) above, outside the stated range (below it).
By their numbers in this assay, from the lowest: compound 4; then compounds 1, 2 and 3 (each within the scatter of the next).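

In this assay, the group on this carbonyl carbon proves able to move the number beyond the scatter: thiophen-2-yl in place of 4-bromophenyl gives a 2.9-fold lower number from compound 1 to compound 4 (0.47 log units; beyond the scatter). The earlier compounds had shown no such separation, so this position is not indifferent to the group it carries. Nothing given here accounts for the step. The compounds shown leave open whether the step belongs to the five-membered ring or to its sulfur. Furan-2-yl or thiophen-3-yl on the same carbon would bear on that question.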